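Series notes: anilino methyl removed, compound 4 pending

A few compounds are considered here, and "the series" means these few. Any claim that something is new, unique, unknown or untested is made for them only; others in the source may bear on it.

Measured so far in a functional assay on Bel-7402 cells (Homo sapiens) for cytotoxicity, read by MTT assay; on this read-out lower numbers stand for stronger inhibition and higher numbers for weaker inhibition:
- compound 1, `COc1cccc(/C=C/C(=O)c2sc(Nc3cccc(C)c3)nc2C)c1`: compound 1 gives > 25000 nM, a limit of the assay.
- compound 2, `Cc1cccc(Nc2nc(C)c(C(=O)/C=C/c3ccccc3Cl)s2)c1`: compound 2 gives > 25000 nM, a limit of the assay.
- compound 3, `Cc1cccc(Nc2nc(C)c(C(=O)/C=C/c3ccccc3)s2)c1`: compound 3 gives > 25000 nM, a limit of the assay.

Compound 2 stands at the limit of > 25000 nM in this assay, at which 3 of the 3 values shown sit, with no number of its own. The single-point steps among the measured compounds are all unreadable: a step that the two limits leave unreadable from compound 1 to compound 2, a step that the two limits leave unreadable from compound 1 to compound 3 and a step that the two limits leave unreadable from compound 2 to compound 3. Among the compounds with values here, the changes at the double-bonded chain carbon, whether 2-chlorophenyl, 3-methoxyphenyl or phenyl, leave every value at the limit, so no size of step is known for this series.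

Compound 4, `Cc1nc(Nc2ccccc2)sc1C(=O)/C=C/c1ccccc1Cl`, differs from compound 2 at the other end: hydrogen in place of methyl on an aromatic carbon. Within the data shown here, none of the measured steps touches this aromatic carbon, so no direct comparison exists. Among the measured compounds shown here, the only guide is that three changes at a distant position all stayed at the limit.

Therefore no readable step is expected from compound 2 to compound 4, with a high chance that this assay again returns only a limit; the estimate for compound 4 is 30000 nM, within 10000 nM to 100000 nM.

The estimated step is a step that the limit leaves unreadable from compound 2 to compound 4, expected to lie within the scatter.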

Compound 4, half-maximal inhibitory concentration: > 25000 nM
Compound 4 was reported as a limit (the forecaster's own chance of this, stated with the estimate: 80%); the middle value does not contradict the limit.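

In this assay compound 4 returns only a limit, as compound 2 does, so no step can be read between compound 2 and compound 4. The compounds shown leave open the actual value of each and the size of any single change, with all of them resting on one limit: the limit of > 25000 nM in this assay, at which 4 of the 4 values shown sit.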